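Thiosemicarbazide series: step from compound 2 to compound 4

This account rests on a few compounds, and the source may have more. Where it says the series, first, only, none or still open, it means among the compounds named here.

Measured so far:
- compound 1, `O=C(NC(=S)NNc1ncnc2ccccc12)c1ccc(C(F)(F)F)cc1`: 10600 nM
- compound 2, `COc1cc2ncnc(NNC(=S)NC(=O)c3cccc(Cl)c3)c2cc1OC`: 4060 nM
- compound 3, `COc1ccccc1C(=O)NC(=S)NNc1ncnc2ccccc12`: 14300 nM

All three numbers come from a functional assay on MGC-803 cells (Homo sapiens) for cytotoxicity, read by MTT assay, with a stated time of 72 h; on this read-out lower numbers stand for stronger inhibition and higher numbers for weaker inhibition. Compound 2 stands lowest of the three; the gap to compound 1 and the gap to compound 3 both lie beyond the usual scatter, so compound 2 is the strongest inhibitor among the measured compounds. Compound 1 and compound 3 differ from compound 2 both in the core and in the aryl group, so none of these gaps can be read as a single-change step.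

Compound 4, `COc1cc2ncnc(NNC(=S)NC(=O)c3ccccc3F)c2cc1OC`, keeps the core of compound 2 and differs from it in one place: 2-fluorophenyl in place of 3-chlorophenyl on a carbonyl carbon. Among the measured compounds shown here, no measured pair shows the effect of this exchange on its own. The aryl groups in the series vary without a clear trend, and the two halogenated rings carry the same count of heavy atoms and no donors or acceptors. In this assay the step from compound 2 to compound 4 is therefore expected to be small, at most a slight loss, and likely within the scatter: a 1.4-fold higher number from compound 2 to compound 4 (0.13 log units; within the scatter). Compound 4 is expected to give about 5500 nM, within a range of 2500 nM to 12000 nM.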

Compound 4, half-maximal inhibitory concentration: 2390 nM
Compound 4: the middle estimate sits 2.3-fold (0.36 log units) above what was measured; the whole stated range lies above it.
By their numbers in this assay, from the lowest: compounds 4 and 2 (each within the scatter of the next); then compounds 1 and 3 (each within the scatter of the next).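

In this assay, replacing 3-chlorophenyl with 2-fluorophenyl on a carbonyl carbon gives a 1.7-fold lower number from compound 2 to compound 4 (0.23 log units; within the scatter), so on this core the place accepts either halogenated phenyl group without a difference that can be told from the scatter. Among the compounds shown here, this is the first single-change step; the gaps involving compound 1 and compound 3 cannot be read, since those compounds differ from compound 2 and compound 4 in both the core and the aryl group. Nothing measured on these groups bears on the result, so the step stands without an explanation.

The groups 3-chlorophenyl and 2-fluorophenyl differ both in the halogen and in where it sits on the ring, and the compounds shown do not separate these two changes. Going by these compounds, it also remains open how this read-out responds on the same core when the group on the carbonyl carbon is not a halogenated phenyl, for example an aminophenyl group, a carboxyphenyl group or a longer alkyl chain.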